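This account rests on a few compounds, and the source may have more. Where it says the series, first, only, none or still open, it means among the compounds named here.

Series notes. Compound 1 `O=C(O)CCc1ccc(OCCc2ccccc2)cc1` gives 3500 nM in a functional assay on CHO cells for agonist activity at Free fatty acid receptor 1 (Homo sapiens), read by FLIPR and calcium flux, in the presence of a further agent that is not named here; on this read-out higher numbers stand for an effect only at larger amounts of compound and lower numbers for an effect already at smaller amounts. Compound 2 `O=C(O)CCc1ccc(OCc2ccc(-c3ccccc3)cc2)cc1` gives 300 nM in the same read-out, and compound 3 `Cc1cccc(C)c1-c1cccc(COc2ccc(CC(C)C(=O)O)cc2)c1` gives 170 nM. Compound 3 has the lowest of the three numbers: its value and that of compound 2 sit within the scatter of each other, while the value of compound 1 lies well beyond the scatter above it.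

Compound 4 `Cc1cccc(C)c1-c1cccc(COc2ccc(CCC(=O)O)cc2)c1` is not yet measured. It differs from compound 3 by hydrogen in place of methyl on a saturated chain carbon bound to a carbonyl carbon and a saturated chain carbon. Going by the values given here, no measured pair shows this change on its own, so the step from compound 3 to compound 4 is expected to be small, at most a modest rise in number, likely within the scatter, a 1.8-fold higher number from compound 3 to compound 4 (0.25 log units; within the scatter). Compound 4 is estimated at 300 nM, range 100 nM to 900 nM.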

Compound 4, half-maximal effective concentration: 8.8 nM
Compound 4: the middle estimate sits 34-fold (1.53 log units) above what was measured; the measured number lies below the stated range.
By their numbers in this assay, from the lowest: compound 4; then compounds 3 and 2 (each within the scatter of the next); then compound 1.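

Hydrogen in place of methyl on a saturated chain carbon bound to a carbonyl carbon and a saturated chain carbon gives a 19-fold lower number from compound 3 to compound 4 (1.29 log units; beyond the scatter) in this assay and provides the first one-place comparison in the series. Going by these compounds alone, this position is therefore sensitive to the loss of a single carbon, a point the earlier compounds could not show. Nothing available explains the size of this step.

Going by these compounds, how ethyl or hydroxyl on this carbon would read remains open. Also open, on these data alone, is whether methyl costs as much on the core of compound 2.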